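Removing a Ring Methyl From a Histamine H3 Amide

The source may report more compounds than this note shows. Statements on the series, on what has been measured and on what is new or still open speak of the compounds shown alone.

The account concerns three anilide amines whose shared core carries a methylpyrrolidinyl-pyrrolidine on one side and an amide on the other. Compound 1 `Cc1cc(N2CCC(N3CCCC3C)C2)ccc1NC(=O)C1C(C)(C)C1(C)C` gives 37.3 nM in an assay on CHO cells for displacement of a labelled ligand from histamine receptor H3 (Macaca mulatta); a higher number here means a weaker inhibitor, a lower number a stronger inhibitor. Compound 2 `CC1CCCN1C1CCN(c2ccc(NC(=O)CC3CCCC3)cc2)C1` gives 3.1 nM in this assay. Compound 3 `Cc1cc(NC(=O)C2C(C)(C)C2(C)C)ccc1N1CCC(N2CCCC2C)C1` gives 65.5 nM in this assay, the highest of the three numbers; compound 1 stands within the scatter of compound 3, while compound 2 stands well beyond it, with a far lower number.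

Compound 4 `CC1CCCN1C1CCN(c2ccc(NC(=O)C3C(C)(C)C3(C)C)cc2)C1` has not been measured. It differs from compound 3 in one place: hydrogen in place of methyl on an aromatic carbon, the position being on the six-membered aromatic ring of carbon only, ortho to a large group and meta to a large group. For the measured compounds named here, no pair of measured compounds shows this single change, so no measured step is available for it. Going by the values given here, compound 2, the only compound without a ring methyl, gives the lowest number, but its amide also differs from that of compound 3, so the comparison is not clean.

Compound 4 is expected to give 30 nM in this assay, with a range from 10 nM to 100 nM. The expected step from compound 3 to compound 4 is a 2.2-fold lower number from compound 3 to compound 4 (0.34 log units; beyond the scatter), a modest move toward a lower number that may not exceed the scatter.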

Compound 4, inhibition constant: 144 nM
The estimate for compound 4 lay 4.8-fold (0.68 log units) below the measured number; measured number above the stated range.
By their numbers in this assay, from the lowest: compound 2; then compounds 1 and 3 (each within the scatter of the next); then compound 4.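

In this assay, taking the methyl off this aromatic carbon, ortho to a large group and meta to a large group, does not lower the number: the change gives a 2.2-fold higher number from compound 3 to compound 4 (0.34 log units; beyond the scatter), and hydrogen in place of the methyl in compound 1, which stands elsewhere on the same ring, gives a 3.9-fold higher number from compound 1 to compound 4 (0.59 log units; beyond the scatter), so both compounds with a ring methyl have lower numbers than their counterpart without one. The low number of compound 2 therefore cannot be credited to the missing ring methyl, since with no ring methyl on either side, 2,2,3,3-tetramethylcyclopropyl in place of cyclopentylmethyl on the carbonyl carbon gives a 46-fold higher number from compound 2 to compound 4 (1.67 log units; beyond the scatter), by far the largest step in the set. Nothing available here bears on what lies behind either change.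

From the compounds shown here alone, whether an ethyl group or a methoxy group on this aromatic carbon would match the methyl remains open. So does whether a ring methyl would give a lower number again when cyclopentylmethyl stands on the carbonyl carbon, as the step seen so far comes only with the 2,2,3,3-tetramethylcyclopropyl amide.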